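The source may hold more compounds than are shown below. What is called first, only, known or untested is meant among the compounds shown, and "the series" means these compounds.

Working notes on the series, read in a functional assay on ACHN cells (Homo sapiens) for antiproliferative activity, read by sulforhodamine B assay; a lower number here means a stronger inhibitor of growth, a higher number a weaker inhibitor of growth. Compound 1 (`CCCCOc1cccc(O)c1C(=O)/C=C/c1ccc(O)cc1`) gives > 30000 nM, and this value is a limit of the assay, not a number. For the measured compounds named here, compound 2 (`CC(C)CCOc1cccc(O)c1C(=O)/C=C/c1ccc(O)cc1`) gives 11300 nM, the only true number so far. The next change leads to compound 3 (`CCC(CC)COc1cccc(O)c1C(=O)/C=C/c1ccc(O)cc1`), with pentan-3-yl in place of isobutyl on a saturated chain carbon bound to an oxygen on an aromatic ring. Cut one bond further out, this reads as isopentyloxy to 2-ethylbutoxy. Going by the values given here, the only measured step that bears on this is an at least 2.6-fold lower number from compound 1 to compound 2 (0.42 log units; beyond the scatter), where a methyl replaces a hydrogen on the chain. Resting on that step alone, a modest further move to a lower number in this assay is expected, and a result within the scatter would not be surprising. On these data alone, one end of that step is a limit, so its true size stays open. The estimated change is a 1.5-fold lower number from compound 2 to compound 3 (0.18 log units; within the scatter). Compound 3 is estimated at 7500 nM, with an expected range of 3000 nM to 25000 nM.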

Compound 3, concentration for 50% growth inhibition: 3370 nM
The estimate for compound 3 lay 2.2-fold (0.35 log units) above the measured number, within the range that was stated.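

In this assay, for the compounds shown here, the change on the saturated chain carbon bound to an oxygen on an aromatic ring, isopentyloxy to 2-ethylbutoxy, gives a 3.4-fold lower number from compound 2 to compound 3 (0.53 log units; beyond the scatter), the first step with a true number at both ends. The three compounds shown all run the same way, with no compound against the pattern, and the span from the shortest chain reads as an at least 8.9-fold lower number from compound 1 to compound 3 (0.94 log units; beyond the scatter). Compound 1 stands at a limit of the assay, so the true size of that span stays open: the limit of > 30000 nM in this assay, at which 1 of the 3 values shown sits.

On these data alone, whether the move to a lower number continues with a longer chain, or holds with a cyclohexylmethyl group or a terminal amine on this oxygen, stays open. The values give no cause for the step, and with one cell line shown they cannot tell whether the same order holds in other cells.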